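Cytotoxicity of a Fourth Carbamate Analogue Expected to Stay Low

This account rests on a few compounds, and the source may have more. Where it says the series, first, only, none or still open, it means among the compounds named here.

Compound 1, `CN(C)c1cc2[nH]c(C3CCCCC3)nc2cc1NC(=O)OCc1ccccc1`, gives > 100 ug/mL in an ADME assay on Vero cells (Chlorocebus sabaeus) for cytotoxicity, read by resazurin assay, with a stated time of 3 days (on this read-out lower numbers stand for stronger inhibition and higher numbers for weaker inhibition), which is a limit of the assay.
Compound 2, `CCCCOC(=O)Nc1cc2nc(C3CCCCC3)[nH]c2cc1N(C)C`, gives > 100 ug/mL in this assay, also a limit.
Compound 3, `CN(C)c1cc2[nH]c(C3CCCCC3)nc2cc1NC(=O)c1ccc(F)cc1F`, gives > 100 ug/mL in this assay, again a limit.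

Compound 3 therefore stands only at the limit, as do the other two values shown (the limit of > 100 ug/mL in this assay, at which 3 of the 3 values shown sit). Compound 4, `CCOCCOC(=O)Nc1cc2nc(C3CCCCC3)[nH]c2cc1N(C)C`, differs from it by 2-ethoxyethoxy in place of 2,4-difluorophenyl on a carbonyl carbon. Within the data shown here, the steps that bear on this change are a step that the two limits leave unreadable from compound 1 to compound 3, a step that the two limits leave unreadable from compound 2 to compound 3 and a step that the two limits leave unreadable from compound 1 to compound 2; none of them has a readable size, since every value sits at the limit. No step beyond the scatter is therefore expected in this assay. From the change alone the expected step is a step that the limit leaves unreadable from compound 3 to compound 4. The expected result for compound 4 is 150 ug/mL, within 80 ug/mL to 300 ug/mL.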

Compound 4, half-maximal inhibitory concentration: > 100 ug/mL
Compound 4: a limit, no number (the forecaster's own chance of this, stated with the estimate: 85%); the middle value does not contradict the limit.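

In this assay compound 4 gives > 100 ug/mL, a limit. No step among compound 1, compound 2, compound 3 and compound 4 can be read: the limit of > 100 ug/mL in this assay, at which 4 of the 4 values shown sit.

The compounds shown leave open how their cytotoxicity compares and what change on the carbonyl carbon, if any, would give a measurable value.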